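Cytotoxicity notes: from compound 2 to compound 4

A few compounds are considered here, and "the series" means these few. Any claim that something is new, unique, unknown or untested is made for them only; others in the source may bear on it.

Measured in an ADME assay on L6 cells (Rattus norvegicus) for cytotoxicity, read by fluorescence and resazurin assay, with a stated time of 72 h; on this read-out higher numbers stand for an effect only at larger amounts of compound and lower numbers for an effect already at smaller amounts:
- compound 1 `O=c1nc(-c2ccccc2)c2cc(-c3cnc4ccccc4c3)ccc2[nH]1`: > 16000 nM
- compound 2 `O=c1nc(-c2ccccc2)c2cc(-c3ccc(F)cc3)ccc2[nH]1`: 50000 nM
- compound 3 `CNC(=O)c1cccc(-c2ccc3[nH]c(=O)nc(-c4ccccc4)c3c2)c1`: > 50000 nM

Going by the values given here, compound 2 holds the only actual number in this small set, 50000 nM. Compound 1 is reported only as a limit of the assay, > 16000 nM. Compound 3 is likewise reported only as a limit of the assay, > 50000 nM.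

Compound 4 `Cn1nccc1-c1ccc2[nH]c(=O)nc(-c3ccccc3)c2c1` has not yet been measured. It carries 1-methyl-1H-pyrazol-5-yl in place of 4-fluorophenyl on an aromatic carbon of the shared core: 1-methyl-1H-pyrazol-5-yl in place of 4-fluorophenyl on an aromatic carbon. Among the compounds with values here, no pair of measured compounds differing in one place is available, so the series gives no direct size for such a change. In this assay no step beyond the usual scatter is expected, and a result reported only as a limit is also plausible. This expectation rests on compound 2 at 50000 nM as the sole numerical anchor. The expected change is no change at the digits printed from compound 2 to compound 4 (within the scatter). For compound 4 the estimated value is 50000 nM, with an expected range of 20000 nM to 100000 nM.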

Compound 4, half-maximal effective concentration: > 50000 nM
Compound 4: only a limit was reported; the forecaster's own chance of this, stated with the estimate: 55%; the middle value sits exactly at the limit.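

In this assay, this place on an aromatic carbon of the shared core now has its first step between measured compounds: 1-methyl-1H-pyrazol-5-yl in place of 4-fluorophenyl gives a number no lower from compound 2 to compound 4 (the limit leaves the size open). Compound 4 is reported as > 50000 nM, a limit of the assay and not a number, and one shared within this small set: the limit of > 50000 nM in this assay, at which 2 of the 4 values shown sit. A five-membered aromatic ring with 2 hetero atoms can therefore replace the six-membered aromatic ring of carbon only without the effect appearing at smaller amounts of compound.

Going by these compounds alone, how large the step is stays open, and compound 2 remains the only compound here with an actual number. Also open, from the compounds shown here alone, is whether an aminomethyl group or a carboxylic acid at this place would shift the effect to smaller amounts of compound.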